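Replacing a Dimethylphenyl Amide with a Pyridyl Amide

This account rests on a few compounds, and the source may have more. Where it says the series, first, only, none or still open, it means among the compounds named here.

Of the compounds shown here, two have so far been measured in a physicochemical assay for lipophilicity, read by HPLC, in phosphate buffer, measured as chromatographic lipophilicity, at pH 7.4; a higher number here means a more lipophilic compound, a lower number a more polar compound. Compound 1, `COc1ccc2nc(C)cc(OC3CCN(c4ccccc4)C3=O)c2c1`, gives 4.99 in this assay. Compound 2, `COc1ccc2nc(C)cc(OCC(=O)Nc3cc(C)ccc3C)c2c1`, gives 5.05 in this assay. Compound 2 holds the higher of the two numbers, but its value lies within the scatter of that of compound 1, so the two cannot be told apart on this evidence. Within the data shown here, no pair of measured compounds differing in a single place is available, so nothing measured yet shows how exchanging the group on the amide nitrogen moves the read-out.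

Compound 3, `COc1ccc2nc(C)cc(OCC(=O)Nc3ccncc3)c2c1`, has not been measured. It differs from compound 2 in one place: pyridin-4-yl in place of 2,5-dimethylphenyl on an amide-type nitrogen. Among the measured compounds shown here, with no measured step to lean on, the expectation rests on the structural change alone, and the step expected here is a number 2.35 log units lower from compound 2 to compound 3 (beyond the scatter), a move toward a lower number that is expected to lie well beyond the scatter. Compound 3 is estimated to give 2.7 in this assay, with a range expected between 2 and 3.4.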

Compound 3, distribution coefficient: 2.5
For compound 3 the middle estimate is 0.20 log units above the measured one, and the stated range covers the measured number.
By their numbers in this assay, from the lowest: compound 3; then compounds 1 and 2 (each within the scatter of the next).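

In this assay pyridin-4-yl in place of 2,5-dimethylphenyl on an amide-type nitrogen brings a number 2.55 log units lower from compound 2 to compound 3 (beyond the scatter) and so shows that the group at this place can move the read-out by a large amount. The earlier compounds shown here could not show this, since they offered no measured pair differing in one place and hence no step at this position. No measurement shown here gives a reason for a step of this size.

The exchange removes both methyl groups and puts a nitrogen into the ring in a single move, so this one step cannot say how much of the change belongs to each part, and pyridin-3-yl, pyridin-2-yl or 2-methylphenyl on the same amide-type nitrogen are the kind of groups that could begin to separate them. Among these compounds, it also remains open whether a step of this size would recur on another scaffold, such as that of compound 1, where the same exchange of groups has no measured pair.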